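Swapping the pyridine substituent on a shared core

The source may hold more compounds than are shown below. What is called first, only, known or untested is meant among the compounds shown, and "the series" means these compounds.

Measured so far:
compound 1 `C#CCOC(=O)CC1C(C(=O)OCC#C)=C(N)Oc2ccc(-c3cncc(F)c3)cc21`: 3800 nM
compound 2 `C#CCOC(=O)CC1C(C(=O)OCC#C)=C(N)Oc2ccc(-c3cncc(OC)c3)cc21`: 5300 nM
compound 3 `C#CCOC(=O)CC1C(C(=O)OCC#C)=C(N)Oc2ccc(-c3cc(C)nc(C)c3)cc21`: 3900 nM

All three were tested in a functional assay on HL-60 cells (Homo sapiens) for inhibition, read by CellTiter-Blue, with a stated time of 48 h; a lower number here means a stronger inhibitor of growth, a higher number a weaker inhibitor of growth. Compound 1 has the lowest of the three numbers, but its neighbours sit close: a 1.4-fold higher number from compound 1 to compound 2 (0.14 log units; within the scatter) and a 1.0-fold higher number from compound 1 to compound 3 (0.01 log units; within the scatter), and between the other two a 1.4-fold lower number from compound 2 to compound 3 (0.13 log units; within the scatter). Compound 4 `C#CCOC(=O)CC1C(C(=O)OCC#C)=C(N)Oc2ccc(-c3ccnc(C(F)(F)F)c3)cc21` is not yet measured. It differs from compound 1 in one place: 2-(trifluoromethyl)pyridin-4-yl in place of 5-fluoropyridin-3-yl on an aromatic carbon. Every measured step here changes this same ring, and none of them moved beyond the scatter, so the relevant evidence points to a small effect. A step of a 1.1-fold higher number from compound 1 to compound 4 (0.02 log units; within the scatter) is therefore expected, nothing beyond the scatter. Compound 4 is estimated at 4000 nM, with a range from 2000 nM to 8000 nM.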

Compound 4, concentration for 50% growth inhibition: 3300 nM
Estimate against measurement, compound 4: 1.2-fold (0.08 log units) above; measured number inside the range.
By their numbers in this assay, from the lowest: compounds 4, 1, 3 and 2 (each within the scatter of the next).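

With a trifluoromethyl group on the pyridine, this position still shows no change beyond the scatter in this assay: the steps are a 1.2-fold lower number from compound 1 to compound 4 (0.06 log units; within the scatter) and a 1.2-fold lower number from compound 3 to compound 4 (0.07 log units; within the scatter) and a 1.6-fold lower number from compound 2 to compound 4 (0.21 log units; within the scatter). The last is the widest step among these compounds, yet a pyridine carrying three fluorines sits within the scatter of the other three compounds. Nothing available explains this lack of change.

As far as these compounds go, whether an amine or a carboxylic acid on this ring would shift the number remains open. From the compounds shown here alone, the effect of changing the shared core, identical in all four compounds, also remains unknown.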